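A few compounds are considered here, and "the series" means these few. Any claim that something is new, unique, unknown or untested is made for them only; others in the source may bear on it.

Working notes on the series. In a functional assay on the whole organism (strain Swiss albino) with Mus musculus as the target, in the maximal electroshock model (on this read-out lower numbers stand for an effect already at smaller amounts and higher numbers for an effect only at larger amounts of compound), compound 1 `COc1ccc(/C=N/Cc2cccnc2)cc1O` gives 6.39 mg/kg. Compound 2 `O=[N+]([O-])c1ccc(/C=N/Cc2cccnc2)cc1` gives 61.4 mg/kg in this assay, the highest of the two numbers recorded so far; its gap to compound 1 lies beyond the scatter. Compound 3 `C(=N/Cc1cccnc1)\c1ccccc1` has not yet been measured in this assay. It differs from compound 2 by hydrogen in place of nitro on an aromatic carbon, para to a group of 9 heavy atoms. Among the compounds with values here, no measured pair shows this exact change, so its size cannot be read off directly; the two recorded values only show that substitution on this ring can shift the number a long way. A moderate move toward lower numbers is expected, of the size a 2.5-fold lower number from compound 2 to compound 3 (0.39 log units; beyond the scatter), though a step within the scatter cannot be excluded. For compound 3 the estimate in this assay is 25 mg/kg, with a range from 8 mg/kg to 80 mg/kg.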

Compound 3, dose for half-maximal effect: 53 mg/kg
Compound 3: middle estimate off by 2.1-fold (0.33 log units), on the low side; the range from low to high includes it.
By their numbers in this assay, from the lowest: compound 1; then compounds 3 and 2 (each within the scatter of the next).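

Hydrogen in place of nitro on an aromatic carbon, para to a group of 9 heavy atoms, is the first single change that can be read in this series, and in this assay it gives a 1.2-fold lower number from compound 2 to compound 3 (0.06 log units; within the scatter). Compounds 2 and 3 therefore cannot be told apart here: at this position, the nitro group and hydrogen give numbers within the scatter of each other, so the nitro group is not required for the number of compound 2. Nothing available explains this result.

From the compounds shown here alone, whether other groups at this position, such as an amine, a carboxylic acid or a longer alkyl chain, would move the number beyond the scatter remains open. The compounds shown also do not separate the contributions of the methoxy and hydroxy groups of compound 1.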